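The compounds below may be only part of what the source reports. "The series", "measured", "known", "first", "only" and "open" are said of these compounds alone.

Three analogues built on a shared core have been tested in a functional assay on NCI-H322M cells (Homo sapiens) for cytotoxicity, read by sulforhodamine B assay, with a stated time of 48 h, tested at 0.01 uM; on this read-out higher numbers stand for a weaker effect at the one concentration tested and lower numbers for a stronger effect. Compound 1 `COc1cc(C)cc(-c2nn(CC#N)cc2-c2ccc(-c3cccc(C(C)=O)c3)nc2)c1` gives 91% in this assay. Compound 2 `Cc1cc(O)cc(-c2nn(CC#N)cc2-c2ccnc(-c3ccc(Oc4ccccc4)cc3)c2)c1` gives 89%. Compound 3 `COc1cc(C)cc(-c2nn(CC#N)cc2-c2ccnc(-c3ccc(N(C)C)cc3)c2)c1` gives 108%, the highest of the three numbers; its nearest neighbour is compound 1, whose number is lower by a difference that lies beyond the usual scatter, and compound 2 sits furthest away, also beyond the scatter. Among the measured compounds shown here, no pair of these measured compounds differs in a single place, so no measured step is available as a guide.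

Compound 4 `Cc1cc(O)cc(-c2nn(CC#N)cc2-c2ccnc(-c3ccc(N(C)C)cc3)c2)c1` has not yet been measured in this assay. It differs from compound 3 in one place: hydrogen in place of methyl on an oxygen on an aromatic ring. Cut one bond further out, the same change reads methoxy to hydroxy, or 3-methoxy-5-methylphenyl to 3-hydroxy-5-methylphenyl.

For the measured compounds named here, with no measured step to rest on, the step from compound 3 to compound 4 is expected to be small, a number 8 percentage points lower from compound 3 to compound 4 (within the scatter), pointing slightly downward but not beyond the scatter. Compound 4 is therefore estimated to give about 100% in this assay, with a range from 85% to 115%.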

Compound 4, a percentage reported as activity, at one concentration (the size of the read-out at that concentration, not a potency): 92%
Beside the measured number, compound 4's estimate is 8 percentage points above it, and the stated range covers the measured number.
By their numbers in this assay, from the lowest: compounds 2, 1 and 4 (each within the scatter of the next); then compound 3.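

In this assay, among the compounds shown here, the change from methoxy to hydroxy, with hydrogen in place of methyl on an oxygen on an aromatic ring, gives the first measured step at this position: a number 16 percentage points lower from compound 3 to compound 4 (beyond the scatter). For the compounds shown here, the number therefore responds to this single change when the rest of the structure, including the dimethylamino group, stays the same, something the earlier compounds could not show because no two of them differed in one place. The second step, with dimethylamino in place of phenoxy on an aromatic carbon and the hydroxy group kept, is a number 3 percentage points higher from compound 2 to compound 4 (within the scatter), so these two groups cannot be told apart here, and nothing available explains either step.

The compounds shown leave open whether the methoxy to hydroxy step keeps its size when phenoxy stands in place of dimethylamino, and how a longer group on that oxygen, such as ethoxy, or an amine in place of the oxygen would read. All these numbers come from a single concentration, so they also leave open how the compounds would compare at other concentrations.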